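Thienyl series: methylsulfanyl to dimethylamino on the core

A few compounds are considered here, and "the series" means these few. Any claim that something is new, unique, unknown or untested is made for them only; others in the source may bear on it.

Measured so far:
compound 1, `C#Cc1cn([C@@H]2O[C@H](CO)[C@@H](O)[C@H]2O)c2ncnc(N(C)C)c12`, 110 nM
compound 2, `CSc1ncnc2c1c(-c1cccs1)cn2[C@@H]1O[C@H](CO)[C@@H](O)[C@H]1O`, 11600 nM

In a functional assay on K562 cells (Homo sapiens), read by MTT assay, with a stated time of 72 h (a higher number here means a weaker inhibitor, a lower number a stronger inhibitor), compound 2 stands at the higher of the two numbers; compound 1 gives 110 nM, a gap beyond the scatter. Compound 1 and compound 2 differ in more than one place, so the two values say nothing about any single change on their own.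

Compound 3, `CN(C)c1ncnc2c1c(-c1cccs1)cn2[C@@H]1O[C@H](CO)[C@@H](O)[C@H]1O`, is not yet measured. It keeps the core and the thienyl substituent of compound 2 and carries the change (dimethylamino in place of methylsulfanyl on an aromatic carbon).

Going by the values given here, no step between measured compounds isolates this change. Among the compounds with values here, compound 1 also carries dimethylamino at the same place on the core and gives 110 nM, which is the only hint that the group is compatible with a low number; the other substituent on the core differs, so the hint is weak. An improvement over compound 2 is expected, of moderate size, with the step of a 4.6-fold lower number from compound 2 to compound 3 (0.67 log units; beyond the scatter) expected to go beyond the scatter. Compound 3 is therefore estimated at 2500 nM, with a range from 400 nM to 12000 nM.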

Compound 3, half-maximal inhibitory concentration: > 20000 nM
Compound 3: no number, only a limit; the forecaster's own chance of this, stated with the estimate: 5%; middle value at least 8.0-fold (0.90 log units) from the limit.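

In this assay, compound 3 has no number, only a limit of the assay: the limit of > 20000 nM in this assay, at which 1 of the 3 values shown sits.

Dimethylamino in place of methylsulfanyl on the aromatic carbon gives an at least 1.7-fold higher number from compound 2 to compound 3 (0.23 log units; that floor lies within the scatter), so this change brings no lower number with the thiophen-2-yl group in place, and the floor of the step does not separate the two compounds beyond the scatter. Going by these compounds alone, with dimethylamino held constant, thiophen-2-yl in place of ethynyl gives an at least 180-fold higher number from compound 1 to compound 3 (2.25 log units; beyond the scatter), so dimethylamino alone does not go with a low number, and the low number of compound 1 is seen only with ethynyl as the other substituent.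

Going by these compounds, how far the true value of compound 3 lies from that of compound 2 stays open, so the size of the step, and whether it goes beyond the scatter, cannot be read. Also open, on these data alone, is how a primary amine or a longer thioether chain such as ethylsulfanyl would behave at this place, and whether methylsulfanyl paired with ethynyl would keep a number close to that of compound 1.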